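This account rests on a few compounds, and the source may have more. Where it says the series, first, only, none or still open, it means among the compounds named here.

Measured compounds:
- compound 1, `O=C(CN1CCN(C(=O)c2ccccc2)CC1)N1CCN(CCCc2c[nH]c3ccccc23)CC1`: > 200000 nM
- compound 2, `O=C(CN1CCN(C(=O)c2ccc(F)cc2)CC1)N1CCN(CCCc2c[nH]c3ccccc23)CC1`: 141000 nM
- compound 3, `O=C(CN1CCN(C(=O)c2ccccc2)CC1)N1CCN(CCCc2c[nH]c3ccc(F)cc23)CC1`: 148000 nM

In an ADME assay on HEK293 cells (Homo sapiens) for cytotoxicity, read by MTT assay, with a stated time of 72 h (on this read-out lower numbers stand for stronger inhibition and higher numbers for weaker inhibition), compound 3 gives 148000 nM, the higher of the two numbers shown, though compound 2 gives 141000 nM, which sits within the scatter of it, so the two cannot be told apart. For compound 1 the value > 200000 nM is a limit of the assay rather than a number.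

Compound 4, `O=C(CN1CCN(C(=O)c2cccc(F)c2)CC1)N1CCN(CCCc2c[nH]c3ccc(F)cc23)CC1`, differs from compound 3 in a single place: fluoro in place of hydrogen on an aromatic carbon. Cut one bond further out, the change reads benzoyl to (3-fluorophenyl)carbonyl. Two measured steps are of the same kind, fluoro in place of hydrogen on an aromatic carbon: an at least 1.4-fold lower number from compound 1 to compound 2 (0.15 log units; that floor lies within the scatter) and an at least 1.3-fold lower number from compound 1 to compound 3 (0.13 log units; that floor lies within the scatter). Both start from compound 1, whose value is the limit of > 200000 nM in this assay, at which 1 of the 3 values shown sits, so only a floor for each step is known, and that floor lies within the scatter. Neither step therefore shows a shift that can be trusted. For the step to compound 4 the expectation is accordingly no change beyond the scatter, a 1.0-fold higher number from compound 3 to compound 4 (0.01 log units; within the scatter), with the chance that the assay again returns only a limit. Compound 4 is thus estimated at 150000 nM, within a range from 70000 nM to 300000 nM.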

Compound 4, half-maximal inhibitory concentration: 83000 nM
The estimate for compound 4 lay 1.8-fold (0.26 log units) above the measured number; the measured number falls inside the stated range.
By their numbers in this assay, from the lowest: compounds 4, 2 and 3 (each within the scatter of the next). At a limit, above all of these: compound 1.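

In this assay, for the compounds shown here, turning benzoyl into (3-fluorophenyl)carbonyl gives the first step of this kind with a real number at both ends: a 1.8-fold lower number from compound 3 to compound 4 (0.25 log units; within the scatter). Compound 1 gives > 200000 nM, which is a limit of the assay and not a number, so the two earlier fluoro steps starting from it fixed only a floor, whereas this step has a known size, and that size does not separate compound 4 from compound 3. Setting this step against the fluoro step on the other core still gives no clear comparison: the same change on two cores in this assay, an at least 1.4-fold lower number (0.15 log units; that floor lies within the scatter) from compound 1 to compound 2 and a 1.8-fold lower number (0.25 log units; within the scatter) from compound 3 to compound 4; the limit leaves it open whether they differ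

Still open, on these data alone, is whether a different group on the same aromatic carbon, such as chloro, methoxy, trifluoromethyl, an amine or a carboxylic acid, would shift the number beyond the usual scatter of repeated measurements. Also open, as far as these compounds go, is whether fluoro on any other carbon of that six-membered ring would give a step that can be told apart from this one, since the values shown here for compounds 2, 3 and 4 all lie within the scatter of the next.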